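A few compounds are considered here, and "the series" means these few. Any claim that something is new, unique, unknown or untested is made for them only; others in the source may bear on it.

- compound 1 `O=C(C[C@]1(O)CC[C@@H](Cc2ccccc2)CC1)Nc1ccc2[nH]c(=O)oc2c1`: 47.4%
- compound 2 `O=C(C[C@]1(O)CC[C@H](Cc2ccccc2)CC1)Nc1ccc2[nH]c(=O)oc2c1`: 33%

In an ADME assay on the whole organism (strain Sprague-Dawley) for pharmacokinetics, with Rattus norvegicus as the target, using cassette dosing, at a dose of 1 mg/kg by the oral route (on this read-out lower numbers stand for lower oral bioavailability and higher numbers for higher oral bioavailability), compound 1 stands highest of the two measured compounds, at 47.4%. Next in line is compound 3 `O=C(C[C@]1(O)CC[C@@H](Cc2ccc(F)cc2)CC1)Nc1ccc2[nH]c(=O)oc2c1`, drawn with the configuration of compound 1. Its structural change is fluoro in place of hydrogen on an aromatic carbon, or phenyl to 4-fluorophenyl. Among the compounds with values here, the only measured step, a number 14.4 percentage points lower from compound 1 to compound 2 (beyond the scatter), is a change of configuration alone (the fact that compounds 1 and 2 differ only in the configuration as drawn). Within the data shown here, no measured step alters the aromatic ring, so that step gives only a rough scale and no direction for the new change. A small change with no step beyond the scatter is therefore expected in this assay. The expected step is a number 0.6 percentage points higher from compound 1 to compound 3 (within the scatter). Compound 3 is estimated at 48%, with an expected range of 30% to 65%.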

Compound 3, oral bioavailability: 42.4%
Compound 3: the middle estimate sits 5.6 percentage points above what was measured; measured number inside the range.
By their numbers in this assay, from the lowest: compounds 2, 3 and 1 (each within the scatter of the next, the first and the last beyond it).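

In this assay, within the data shown here, the first read on the aromatic ring is a number 5 percentage points lower from compound 1 to compound 3 (within the scatter), so fluoro on this aromatic carbon, para to a large group, gives no step that can be told from hydrogen. Among the steps at hand, the change of configuration, a number 14.4 percentage points lower from compound 1 to compound 2 (beyond the scatter), remains the only one beyond the scatter, and the benzyl to 4-fluorobenzyl change leaves the oral read-out of the configuration of compound 1 unresolved from the parent. Nothing at hand bears on why this step is as small as it is.

Open, as far as these compounds go, is whether a larger or charged group at this carbon, such as methoxy, an amine or a carboxylic acid, would give a step beyond the scatter. Also open, from the compounds shown here alone, is whether fluoro behaves alike on the configuration of compound 2.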